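The source may report more compounds than this note shows. Statements on the series, on what has been measured and on what is new or still open speak of the compounds shown alone.

Compound 1 `Clc1ccc(-c2ccnc3c2c(-c2ccccc2)nn3-c2ccccc2)cc1` and compound 2 `COc1ccc(-c2ccnc3c2c(-c2ccccc2)nn3-c2ccccc2)cc1` share one core and differ only in the change (methoxy in place of chloro on an aromatic carbon). In a functional assay on HepG2 cells (Homo sapiens) for inhibition, read by MTT assay, with a stated time of 48 h (on this read-out lower numbers stand for stronger inhibition and higher numbers for weaker inhibition), compound 1 gives 61100 nM, and in this assay compound 2 gives 6590 nM, so the change made a step of a 9.3-fold lower number from compound 1 to compound 2 (0.97 log units; beyond the scatter). Compound 3 `CN1CCN(c2ccc(-c3c(C#N)c(-c4ccc(Cl)cc4)nc4c3c(-c3ccccc3)nn4-c3ccccc3)cc2)CC1` carries a different core, and the difference between the two cores is not broken down here. In this assay compound 3 gives 14600 nM. Compound 4 `COc1ccc(-c2nc3c(c(-c4ccccc4)nn3-c3ccccc3)c(-c3ccc(N4CCN(C)CC4)cc3)c2C#N)cc1` is reached from compound 3 by the same change, (methoxy in place of chloro on an aromatic carbon), at the same kind of place. If the step repeats, the number for compound 4 is expected to fall by about a 5.8-fold lower number from compound 3 to compound 4 (0.77 log units; beyond the scatter) in this assay, resting on the step seen from compound 1 to compound 2. Compound 4 is therefore estimated to give 2500 nM in this assay, roughly between 700 nM and 9000 nM.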

Compound 4, half-maximal inhibitory concentration: 1330 nM
Compound 4: the middle estimate sits 1.9-fold (0.27 log units) above what was measured, within the range that was stated.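

In this assay, replacing 4-chlorophenyl with 4-methoxyphenyl made an 11-fold lower number from compound 3 to compound 4 (1.04 log units; beyond the scatter), and the step kept its size when carried from one core to the other: the same change on two cores in this assay, a 9.3-fold lower number (0.97 log units; beyond the scatter) from compound 1 to compound 2 and an 11-fold lower number (1.04 log units; beyond the scatter) from compound 3 to compound 4, 1.2-fold (0.07 log units) apart, within the scatter of two such steps. In this series, then, the earlier step was a fair guide to the new one, even though the two cores differ. For the compounds shown here, this rests on only two pairs of compounds, so it does not make a rule for other cores, and it does not show why the number falls.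

The compounds shown leave open what other groups at the same place would do, such as an amine, a carboxylic acid or a longer ether chain like ethoxy. They also leave open how a plain hydrogen there would compare with chloro and methoxy.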